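Swapping the aryl group on the piperazine in an anticonvulsant series

This account rests on a few compounds, and the source may have more. Where it says the series, first, only, none or still open, it means among the compounds named here.

Of the compounds shown here, two of a shared core have been tested so far. Compound 1 `CCC1(C)CC(=O)N(CC(=O)N2CCN(c3ccccc3Cl)CC2)C1=O` carries a 2-chlorophenyl group and compound 2 `CC1CC(=O)N(CC(=O)N2CCN(c3ccc(F)cc3)CC2)C1=O` carries a 4-fluorophenyl group on the ring amine. In a functional assay on the whole organism (strain CD1) with Mus musculus as the target, in the maximal electroshock model (a lower number here means that less compound is needed, a higher number that more compound is needed for the effect), compound 1 gives 122 mg/kg and compound 2 gives 87.4 mg/kg. Compound 2 thus stands at the lower of the two values, but the gap to compound 1 lies within the scatter of the method, so the two cannot be told apart.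

Compound 3 `CC1CC(=O)N(CC(=O)N2CCN(c3ccc(Cl)c(Cl)c3)CC2)C1=O` is the next step: 3,4-dichlorophenyl in place of 4-fluorophenyl on an amine nitrogen in a ring. Within the data shown here, no measured pair shows what this kind of change does, so the expectation rests on the closeness of compounds 1 and 2 alone. A step from compound 2 to compound 3 of a 1.2-fold lower number from compound 2 to compound 3 (0.07 log units; within the scatter) is expected, small and possibly not beyond the scatter. For compound 3 the estimate in this assay is 75 mg/kg, within a range of 35 mg/kg to 160 mg/kg.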

Compound 3, dose for half-maximal effect: 75.6 mg/kg
For compound 3 the middle estimate is 1.0-fold (0.00 log units) below the measured one; low and high end bracket the measured number.
By their numbers in this assay, from the lowest: compounds 3, 2 and 1 (each within the scatter of the next).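

The first exchange measured at this place shows that, in this assay, 3,4-dichlorophenyl in place of 4-fluorophenyl on the amine nitrogen in the ring gives a 1.2-fold lower number from compound 2 to compound 3 (0.06 log units; within the scatter) and so the two compounds cannot be told apart. For this pair, then, going from one fluorine to two chlorine atoms on the phenyl ring leaves the dose needed in the mouse indistinguishable. Nothing shown here explains why the two numbers stay so close.

As far as these compounds go, it remains open whether this place also accepts aryl groups of a different kind, such as a pyridine ring, or a phenyl ring carrying a methoxy group or a carboxylic acid, and whether any of these would give a step beyond the scatter. From the compounds shown here alone, it is equally open whether the same exchange gives a similar step on the core of compound 1.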